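The compounds below may be only part of what the source reports. "The series", "measured", "known", "first", "only" and "open" are said of these compounds alone.

Compound 1 `C=CCOc1ccc(F)cc1C(=O)c1cccnc1` gives 91000 nM in a functional assay on IMR-32 cells (Homo sapiens) for cytotoxicity, read by sulforhodamine B assay, with a stated time of 48 h (on this read-out higher numbers stand for weaker inhibition and lower numbers for stronger inhibition), and stands level with compound 3 `C=CCOc1c(Cl)cccc1C(=O)c1cccnc1` at 94000 nM on these numbers, while compound 2 `O=C(c1cccnc1)c1cc(F)ccc1O` at 6210 nM lies far lower. Compound 4 `C=CCOc1ccc(Cl)cc1C(=O)c1cccnc1` differs from compound 1 by one change chloro in place of fluoro on an aromatic carbon in words chloro in place of fluoro on an aromatic carbon. For the measured compounds named here, the only measured step runs a 15-fold lower number from compound 1 to compound 2 (1.17 log units; beyond the scatter) and is large, but it puts hydrogen in place of allyl on an oxygen, which compound 4 does not do. Compound 3 also carries chloro and gives 94000 nM within the scatter of compound 1, so no step beyond the scatter is expected in this assay in either direction. The expected change is only a 1.1-fold lower number from compound 1 to compound 4 (0.03 log units; within the scatter) and nothing more. Compound 4 is estimated at 85000 nM with an expected range from 45000 nM to 160000 nM for its measurement.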

Compound 4, half-maximal inhibitory concentration: 91000 nM
Estimate against measurement, compound 4: 1.1-fold (0.03 log units) below, within the range that was stated.
By their numbers in this assay, from the lowest: compound 2; then compounds 1, 4 and 3 (each within the scatter of the next).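

In this assay there is no change at the digits printed from compound 1 to compound 4 (within the scatter) when chloro replaces fluoro on the aromatic carbon para to an allyloxy group. With the allyloxy group in place, this carbon carries either halogen without a step beyond the scatter, unlike the large step on the oxygen seen earlier. No evidence here bears on this result. The compounds shown leave open whether a methoxy group, an amine or a carboxylic acid on this carbon would move the number, and whether hydrogen in place of allyl gives a similar step with chloro present.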